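This account rests on a few compounds, and the source may have more. Where it says the series, first, only, none or still open, it means among the compounds named here.

Measured compounds in a functional assay on HL-60 cells (Homo sapiens) for cytotoxicity, read by WST assay, with a stated time of 48 h; a lower number here means a stronger inhibitor, a higher number a weaker inhibitor:
compound 1 `COc1ccccc1/C=C/C[C@H]1C[C@@H]([C@@H](O)c2ccccc2)CO[C@@H]1c1ccccc1` gives 10100 nM
compound 2 `O=[N+]([O-])c1ccccc1/C=C/C[C@H]1C[C@@H]([C@@H](O)c2ccccc2)CO[C@@H]1c1ccccc1` gives 7250 nM
compound 3 `COc1ccc(/C=C/C[C@H]2C[C@H]([C@H](O)c3ccc(OC)c(OC)c3)CO[C@@H]2c2ccc(OC)c(OC)c2)cc1OC` gives 23500 nM

Among these three numbers compound 1 stands second highest; compound 2 lies nearest, within the scatter, and compound 3 furthest, beyond it. The unmeasured compound 4 `O=[N+]([O-])c1ccc(/C=C/C[C@H]2C[C@@H]([C@@H](O)c3ccccc3)CO[C@@H]2c2ccccc2)cc1` differs from compound 1 by 4-nitrophenyl in place of 2-methoxyphenyl on a double-bonded chain carbon bound to a double-bonded chain carbon. Among the measured compounds shown here, the only measured step that bears on this change is the one in which a nitro group replaces a methoxy group on the same aromatic ring: a 1.4-fold lower number from compound 1 to compound 2 (0.14 log units; within the scatter). That step stayed within the scatter, so no shift beyond the scatter is expected in this assay for compound 4 either. Compound 4 is therefore estimated at 8500 nM, with a range from 4000 nM to 18000 nM, which means an expected step of a 1.2-fold lower number from compound 1 to compound 4 (0.07 log units; within the scatter).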

Compound 4, half-maximal inhibitory concentration: 4880 nM
For compound 4 the middle estimate is 1.7-fold (0.24 log units) above the measured one; the measured number falls inside the stated range.
By their numbers in this assay, from the lowest: compounds 4, 2 and 1 (each within the scatter of the next, the first and the last beyond it); then compound 3.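

In this assay, among the compounds shown here, 4-nitrophenyl gives the only step at this position that lies beyond the scatter (a 2.1-fold lower number from compound 1 to compound 4 (0.32 log units; beyond the scatter)). Against 2-nitrophenyl, the same group stays within the scatter (a 1.5-fold lower number from compound 2 to compound 4 (0.17 log units; within the scatter)), so this assay does not separate the two nitrophenyl groups, and the shift from compound 1 is small. Nothing measured here accounts for either step. The compounds shown leave open how an amine or a carboxylic acid would read in place of the nitro group on this ring. They also leave open what a longer chain would do at this place.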